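The compounds below may be only part of what the source reports. "The series", "measured", "known", "first", "only" and "open" are said of these compounds alone.

Compound 1, `CC(C)NC1=NS(=O)(=O)c2cc(Cl)c(Cl)cc2N1`, gives 2300 nM in a functional assay (aorta) with Rattus norvegicus as the target, with a stated time of 90 min, at 37 degrees C; a higher number here means that more compound is needed for the effect, a lower number that less compound is needed.
Compound 2, `CCNC1=NS(=O)(=O)c2cc(F)c(Cl)cc2N1`, gives 42400 nM in this assay.
Compound 3, `CC(C)NC1=NS(=O)(=O)c2cc(F)c(Cl)cc2N1`, gives 41500 nM in this assay.

The shared core is changed from compound 1 to compound 3 by fluoro in place of chloro on an aromatic carbon, and this brings an 18-fold higher number from compound 1 to compound 3 (1.26 log units; beyond the scatter). Compound 2 and compound 3 differ only in the amine substituent, and there a 1.0-fold lower number from compound 2 to compound 3 (0.01 log units; within the scatter), so the two cannot be told apart. How the cores of compound 1 and compound 2 differ is not broken down here.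

Compound 4, `CCNC1=NS(=O)(=O)c2cc(F)c(F)cc2N1`, is built from compound 2 by fluoro in place of chloro on an aromatic carbon. Around the place the surroundings are not identical, since in compound 1 the carbon is ortho to a chloro group, whereas in compound 2 it is ortho to a fluoro group; the change is therefore the same kind of change rather than the same change. Because compound 1 to compound 3 shows an 18-fold higher number from compound 1 to compound 3 (1.26 log units; beyond the scatter), a step of similar direction is expected for compound 4, namely a 5.9-fold higher number from compound 2 to compound 4 (0.77 log units; beyond the scatter) in this assay. Compound 4 is thus estimated at 250000 nM, probably between 70000 nM and 900000 nM.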

Compound 4, half-maximal effective concentration: 66700 nM
Estimate against measurement, compound 4: 3.7-fold (0.57 log units) above; measured number below the stated range.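

In this assay, swapping chloro for fluoro on the core of compound 2 gives a 1.6-fold higher number from compound 2 to compound 4 (0.20 log units; within the scatter), so on this core the change leaves no clear mark. Set beside the earlier case, the same swap does not carry over from one core to another with a fixed size: the same change on two cores in this assay, an 18-fold higher number (1.26 log units; beyond the scatter) from compound 1 to compound 3 and a 1.6-fold higher number (0.20 log units; within the scatter) from compound 2 to compound 4, 11-fold (1.06 log units) apart, beyond the scatter of two such steps These two pairs show only that the size of the step depends on the core; they differ both in the amine substituent and in the halogen group that stays on the ring, and they cannot show which of these matters.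

Still open, as far as these compounds go, is how the compound that joins the amine substituent of compound 2 to the chloro groups of compound 1 would stand, since it would help separate these two differences. Also open, from the compounds shown here alone, is what bromo or methoxy at this aromatic carbon, or a longer chain on the amine, would do to the number.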